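The compounds below may be only part of what the source reports. "The series", "measured", "known", "first", "only" and "open" are said of these compounds alone.

Measured compounds:
- compound 1, `CC(C(=O)N1CCN(c2ccccc2C(F)(F)F)CC1)N1C(=O)CCC1=O`: 25%
- compound 2, `COc1cccc(N2CCN(C(=O)C(C)N3C(=O)CCC3=O)CC2)c1`: 0%
- compound 3, `CC(C(=O)N1CCN(c2ccc(Cl)cc2)CC1)N1C(=O)CCC1=O`: 0%

In a functional assay on the whole organism (strain Swiss) with Mus musculus as the target, in the maximal electroshock model, with a stated time of 1 h, at a dose of 100 mg/kg by the intraperitoneal route (on this read-out higher numbers stand for a stronger effect at the one dose given and lower numbers for a weaker effect), compound 3 stands level with compound 2, and together the two give the lowest of the three numbers. Among the compounds with values here, the one higher number belongs to compound 1, whose value in this assay is 25%; no single-place step connects compound 1 to compound 3, so only the two values themselves can be compared.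

The unmeasured compound 4, `CC(C(=O)N1CCN(c2cccc(F)c2)CC1)N1C(=O)CCC1=O`, differs from compound 3 in one place: 3-fluorophenyl in place of 4-chlorophenyl on an amine nitrogen in a ring.

Within the data shown here, one measured step bears on this change, the exchange of one aryl group for another on the same ring nitrogen: no change at the digits printed from compound 2 to compound 3 (within the scatter). That swap left the number unchanged within the scatter. The step to compound 4 is of the same kind, and no measured step among these compounds shows a move upward from an aryl swap of this sort, so no change beyond the scatter is expected: a number 5 percentage points higher from compound 3 to compound 4 (within the scatter). Compound 4 is therefore estimated at 5%, within a range of 0% to 25%.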

Compound 4, a percentage reported as activity, at one dose (the size of the read-out at that dose, not a potency): 0%
Beside the measured number, compound 4's estimate is 5 percentage points above it; the range from low to high includes it.
By their numbers in this assay, from the lowest: compounds 2, 3 and 4 (each within the scatter of the next); then compound 1.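

In this assay, the exchange of 4-chlorophenyl for 3-fluorophenyl on the amine nitrogen gives no change at the digits printed from compound 3 to compound 4 (within the scatter), and the exchange of methoxy for fluoro gives no change at the digits printed from compound 2 to compound 4 (within the scatter). A third aryl group on this ring nitrogen therefore reads the same at this one dose, so compounds 2, 3 and 4 now form a set of three with no difference between them, while compound 1, which carries trifluoromethyl on its phenyl, goes against that pattern with 25%. No measurement offered here explains these values.

On these data alone, what remains open is whether the higher number of compound 1 is particular to trifluoromethyl. As far as these compounds go, it is also open whether a nitrile or an amine on the phenyl would give a number beyond the scatter of these three compounds.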